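The source may report more compounds than this note shows. Statements on the series, on what has been measured and on what is new or still open speak of the compounds shown alone.

Three compounds share one core and differ only in the group on the outer benzyl ring. Compound 1 `COc1cccc(OC)c1OCCNCCOc1ccccc1OCc1cccc(Cl)c1` gives 8.72 in a functional assay on thoracic aorta for antagonist activity at Alpha-1D adrenergic receptor (Rattus norvegicus); on this read-out lower numbers stand for lower potency and higher numbers for higher potency (the scale is a negative logarithm). Compound 2 `COc1cccc(OC)c1OCCNCCOc1ccccc1OCc1cccc(C)c1` gives 8.85. Compound 3 `COc1cccc(OC)c1OCCNCCOc1ccccc1OCc1ccc(C)cc1` gives 9.12, the highest of the three numbers; its nearest neighbour is compound 2, at a distance within the scatter, and its furthest is compound 1, with a step of a number 0.40 log units higher from compound 1 to compound 3 (beyond the scatter).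

Compound 4 `COc1cccc(OC)c1OCCNCCOc1ccccc1OCc1ccc([N+](=O)[O-])cc1` has not been measured in this assay. It differs from compound 3 by nitro in place of methyl on an aromatic carbon, on an aromatic carbon of a six-membered aromatic ring of carbon only, para to a large group. Among the compounds with values here, the only measured step that swaps one small aromatic group for another at a fixed place is a number 0.13 log units higher from compound 1 to compound 2 (within the scatter), and a number 0.27 log units higher from compound 2 to compound 3 (within the scatter) moves the same group to another place. Both are small. Within the data shown here, no step involving a nitro group has been measured, so the expectation rests on the small size of these substituent swaps.

On that basis compound 4 is expected to give 8.9, with a range from 8.4 to 9.4. That estimate means an expected step of a number 0.22 log units lower from compound 3 to compound 4 (within the scatter), no change beyond the scatter.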

Compound 4, negative logarithm of the antagonist equilibrium constant: 9.41
Beside the measured number, compound 4's estimate is 0.51 log units below it; the whole stated range lies below it.
By their numbers in this assay, from the lowest: compounds 1, 2, 3 and 4 (each within the scatter of the next, the first and the last beyond it).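

In this assay, the aromatic carbon para to a large group takes nitro in place of methyl with no change beyond the scatter (a number 0.29 log units higher from compound 3 to compound 4 (within the scatter)), even though nitro brings more heavy atoms and two hydrogen-bond acceptors that methyl lacks. The 4-nitrophenyl group also stands clear of the groups in the two earlier compounds, 3-methylphenyl (a number 0.56 log units higher from compound 2 to compound 4 (beyond the scatter)) and 3-chlorophenyl (a number 0.69 log units higher from compound 1 to compound 4 (beyond the scatter)), and these are modest steps. No measurement at hand explains why this swap leaves the number within the scatter.

As far as these compounds go, what an amine, a carboxylic acid or a methoxy group would give at this same place remains open. So does whether a longer chain there would keep the number in this range.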